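The source may report more compounds than this note shows. Statements on the series, on what has been measured and on what is new or still open speak of the compounds shown alone.

The series shares one core, seen in compound 1 `COc1ccc(-c2cnc(NC(=O)c3ccccc3C)n2C)cc1` and compound 2 `COc1ccc(-c2cnc(NC(=O)c3ccc(C)cc3)n2C)cc1`, which differ only in the group on the carbonyl carbon. In a toxicity assay on THP-1 cells (Homo sapiens) for inhibition (a higher number here means that more compound is tolerated, a lower number that less compound is tolerated), compound 1 gives > 100000 nM, which is a limit of the assay and not a number. In this assay compound 2 likewise gives > 100000 nM, again only a limit. The step that the two limits leave unreadable from compound 1 to compound 2 therefore cannot be read in size. Both values sit at the limit of > 100000 nM in this assay, at which 2 of the 2 values shown sit, so compound 2 stands at the edge of what the assay reports, with no further number to place it more closely.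

Compound 3 `COc1ccc(-c2cnc(NC(=O)C3CCCCC3)n2C)cc1` differs from compound 2 in one place: cyclohexyl in place of 4-methylphenyl on a carbonyl carbon. Within the data shown here, the single measured step bears on this only by showing that one exchange of the group on the carbonyl carbon left both compounds at the limit. Compound 3 is therefore expected to stay at the limit as well, with a step of a number no higher from compound 2 to compound 3 (the limit leaves the size open) that lies within the scatter. The estimate for compound 3 in this assay is 100000 nM, with a range from 50000 nM to 300000 nM.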

Compound 3, half-maximal cytotoxic concentration: > 100000 nM
Compound 3 gave a limit, no number (the forecaster's own chance of this, stated with the estimate: 85%); the middle value sits exactly at the limit.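

Compound 3 ends at a limit of the assay in this assay, as compound 1 and compound 2 do, so no step among these three compounds can be read in size: the limit of > 100000 nM in this assay, at which 3 of the 3 values shown sit.

The compounds shown leave open how much of any of them the cells tolerate, and whether any group on the carbonyl carbon changes that.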